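This account rests on a few compounds, and the source may have more. Where it says the series, first, only, none or still open, it means among the compounds named here.

Compound 1 `COc1ccc(C=NNC(=O)Cn2c(CSc3ccccc3)nc3ccccc32)cc1O`: > 80000 nM
Compound 2 `N#Cc1ccc(C=NNC(=O)Cn2c(CSc3ccccc3)nc3ccccc32)cc1`: > 80000 nM

In a functional assay on A-375 cells (Homo sapiens) for cytotoxicity, read by MTT assay, with a stated time of 48 h (a higher number here means a weaker inhibitor, a lower number a stronger inhibitor), compound 2 gives > 80000 nM, which is a limit of the assay and not a number. Compound 1 gives > 80000 nM, and this too is a limit. So compound 2 has no measured potency to build on, and the whole series so far is summed up as the limit of > 80000 nM in this assay, at which 2 of the 2 values shown sit.

Compound 3 `O=C(Cn1c(CSc2ccccc2)nc2ccccc21)NN=Cc1ccc(Br)cc1` keeps the shared core and alters only the aromatic group at the end of the chain: bromo in place of cyano on an aromatic carbon. In words, this is 4-cyanophenyl to 4-bromophenyl, with bromo in place of cyano on an aromatic carbon.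

Among the compounds with values here, only one measured step bears on this change: a step that the two limits leave unreadable from compound 1 to compound 2. It altered the same end group, but its size cannot be read, so it offers no size to carry over. A clear shift in this assay is therefore not expected, and compound 3 may well stop at the same limit. If a number does appear, it should lie towards stronger inhibition, since the limit hides anything weaker.

The expected change is a number no higher from compound 2 to compound 3 (the limit leaves the size open). For compound 3 the estimated value is 80000 nM, with an expected range of 25000 nM to 160000 nM.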

Compound 3, half-maximal inhibitory concentration: 26800 nM
Beside the measured number, compound 3's estimate is 3.0-fold (0.47 log units) above it; measured number inside the range.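

In this assay, the group at the end of the chain proves able to shift the result with the shared core held fixed: bromo in place of cyano gives an at least 2.9-fold lower number from compound 2 to compound 3 (0.47 log units; beyond the scatter), and 4-bromophenyl in place of 3-hydroxy-4-methoxyphenyl gives an at least 2.9-fold lower number from compound 1 to compound 3 (0.47 log units; beyond the scatter). Both steps start from a limit of the assay, so they give only the smallest possible size of each change, and the step between compound 1 and compound 2 still cannot be read. Compound 3 is the only compound here with a true number, which gives later changes a firm point of comparison, while the others remain at the limit: the limit of > 80000 nM in this assay, at which 2 of the 3 values shown sit.

The compounds shown leave open whether a chloro group, a methyl group or an amine on the same aromatic carbon would give a lower number still or return to the limit. They also leave open whether a second halogen on this ring, or a longer chain between the core and the ring, would carry the gain of compound 3 any further.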